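Hydroxy and methoxy swapped on a hydrazone for maltase-glucoamylase

A few compounds are considered here, and "the series" means these few. Any claim that something is new, unique, unknown or untested is made for them only; others in the source may bear on it.

Compound 1 `O=C(N/N=C/c1ccc(O)c(O)c1)c1ccc(-c2nc3ccccc3s2)cc1`: 15100 nM
Compound 2 `COc1ccc(/C=N/NC(=O)c2ccc(-c3nc4ccccc4s3)cc2)cc1O`: "not active" (no number reported)

Of the compounds shown here, two with a shared core have been tested in an assay on isolated protein for inhibition of Maltase-glucoamylase (Homo sapiens), with a stated time of 15 min; on this read-out lower numbers stand for stronger inhibition and higher numbers for weaker inhibition. Compound 1 gives 15100 nM, a weak result. Compound 2 is reported in this assay as "not active" (no number reported), so no number exists for it, and its distance from compound 1 cannot be expressed as a step. Compound 3 `COc1cc(/C=N/NC(=O)c2ccc(-c3nc4ccccc4s3)cc2)ccc1O` has not yet been measured. It differs from compound 2 as follows: 4-hydroxy-3-methoxyphenyl in place of 3-hydroxy-4-methoxyphenyl on a carbon with a double bond to nitrogen. For the measured compounds named here, no measured pair shows what such a change does here, so the size of the step from compound 2 remains open. Compound 1, carrying two hydroxy groups, is only weakly active, while compound 2, carrying a hydroxy and a methoxy group, gives no number at all; compound 3 carries the same groups as compound 2. Compound 3 is therefore expected to stay weak, around 30000 nM, in a range from 8000 nM to 120000 nM, with a real chance that only "not active" is reported.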

Compound 3, half-maximal inhibitory concentration: 53300 nM
Compound 3: middle estimate off by 1.8-fold (0.25 log units), on the low side; low and high end bracket the measured number.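

Adding a methyl to one hydroxy oxygen of compound 1 gives a 3.5-fold higher number from compound 1 to compound 3 (0.55 log units; beyond the scatter) in this assay, the first measured size for this change on the shared core. Compound 3, which carries 4-hydroxy-3-methoxyphenyl, gives 53300 nM, while compound 2, with the same two groups arranged as 3-hydroxy-4-methoxyphenyl, is reported as "not active"; here, the arrangement of the groups goes with whether a number is obtained, although no step can be read for this pair. Nothing shown gives a reason for either result.

From the compounds shown here alone, what an amine or a carboxylic acid would do in place of the hydroxy group remains open. So does whether an ethoxy group, with its longer chain, would weaken inhibition further than the methoxy group.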